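The source may hold more compounds than are shown below. What is called first, only, known or untested is meant among the compounds shown, and "the series" means these compounds.

In an assay for inhibition of Alpha amylase (Homo sapiens), with a stated time of 10 min; on this read-out lower numbers stand for stronger inhibition and higher numbers for weaker inhibition:
compound 1 `COc1ccc(/C=N/n2cnnc2)c(OC)c1` gives 4370 nM
compound 2 `CCOc1ccc(/C=N/n2cnnc2)cc1OC` gives 5240 nM
compound 3 `Clc1ccc(/C=N/n2cnnc2)cc1` gives 4360 nM

Compound 2 returns the largest of the three numbers, but its gaps to compound 1 and to compound 3 both fall within the scatter, so the three cannot be separated on these data. Compound 4 `COc1cc(/C=N/n2cnnc2)ccc1F` arises from compound 2 by fluoro in place of ethoxy on an aromatic carbon. Among the measured compounds shown here, no measured pair shows this exchange, so its effect in this assay cannot be read from the series. With the three measured values lying within scatter of one another, no step beyond the scatter is anticipated in either direction. Compound 4 is therefore expected to come in around 5000 nM, with a range of 2500 nM to 10000 nM. The step from compound 2 to compound 4 implied by this estimate is a 1.0-fold lower number from compound 2 to compound 4 (0.02 log units; within the scatter).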

Compound 4, half-maximal inhibitory concentration: 2330 nM
For compound 4 the middle estimate is 2.1-fold (0.33 log units) above the measured one, and the stated range ends above it.
By their numbers in this assay, from the lowest: compounds 4, 3, 1 and 2 (each within the scatter of the next, the first and the last beyond it).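

In this assay, among the compounds shown here, the aromatic carbon ortho to a methoxy group is the first place where a single exchange moves the number beyond the scatter: fluoro in place of ethoxy gives a 2.2-fold lower number from compound 2 to compound 4 (0.35 log units; beyond the scatter) as a modest step. This one pair cannot separate the loss of ethoxy from the gain of fluoro, and nothing available explains the step. Open, as far as these compounds go, is how an amino group, a hydroxyl group or a longer butoxy chain at this carbon would read, and whether the step carries over to other substitution on the shared core.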